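Anilino variation in a thioether-bearing series against PC-3 cells

The source may report more compounds than this note shows. Statements on the series, on what has been measured and on what is new or still open speak of the compounds shown alone.

Measured compounds:
compound 1, `CCCCCCCCCCCCCCNc1nc(SCc2ccc(C(F)(F)F)cc2)nc2ccccc12` — > 50000 nM
compound 2, `CCOc1ccccc1Nc1nc(SCc2ccc(C(F)(F)F)cc2)nc2ccccc12` — 26200 nM

Two compounds have been run in a functional assay on PC-3 cells (Homo sapiens) for cytotoxicity, read by MTT assay, with a stated time of 72 h; a lower number here means a stronger inhibitor, a higher number a weaker inhibitor. Compound 1, `CCCCCCCCCCCCCCNc1nc(SCc2ccc(C(F)(F)F)cc2)nc2ccccc12`, returns only a limit of the assay, > 50000 nM. Within the data shown here, compound 2, `CCOc1ccccc1Nc1nc(SCc2ccc(C(F)(F)F)cc2)nc2ccccc12`, gives 26200 nM in this assay and so carries the only real number in the set. The other entry is a limit, as noted in the limit of > 50000 nM in this assay, at which 1 of the 2 values shown sits, so compound 2 cannot be placed relative to anything else beyond the fact that it gives a number where compound 1 does not.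

Compound 3, `COc1ccc(Nc2nc(SCc3ccc(C(F)(F)F)cc3)nc3ccccc23)cc1`, is the next step from compound 2. The change is 4-methoxyphenyl in place of 2-ethoxyphenyl on a nitrogen on an aromatic ring. Among the measured compounds shown here, no pair of measured compounds differs in a single place, so there is no measured step to lean on for size or direction. The expectation is a step from compound 2 to compound 3 of a 1.0-fold lower number from compound 2 to compound 3 (0.02 log units; within the scatter), that is, none beyond the usual scatter, with compound 3 staying in the weak range that compound 2 occupies at 26200 nM. Compound 3 is accordingly estimated at 25000 nM, within 8000 nM to 80000 nM, with a real chance that the assay again returns only a limit.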

Compound 3, half-maximal inhibitory concentration: 16700 nM
Compound 3: middle estimate off by 1.5-fold (0.18 log units), on the high side; low and high end bracket the measured number.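

In this assay, placing 4-methoxyphenyl in place of 2-ethoxyphenyl on a nitrogen on an aromatic ring gives a 1.6-fold lower number from compound 2 to compound 3 (0.20 log units; within the scatter). Among these compounds, this is the only single-place step available so far, and it shows that this exchange does not move the read-out beyond the usual scatter, with both compounds still giving real numbers rather than a limit of the assay. Compound 1 remains the one entry that is only a limit, so the series still has a single measured step and an open lower edge: the limit of > 50000 nM in this assay, at which 1 of the 3 values shown sits.

The step changes the alkoxy group and its place on the phenyl ring together, so 2-ethoxyphenyl and 4-methoxyphenyl alone cannot show which of the two changes matters, or whether either does; a comparison with 2-methoxyphenyl or 4-ethoxyphenyl would separate them. Also open, as far as these compounds go, is whether a phenyl ring carrying an amine or a carboxylic acid on this nitrogen would take the number beyond the scatter of the two alkoxy compounds.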